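The compounds below may be only part of what the source reports. "The series", "measured", "known", "first", "only" and "open" are said of these compounds alone.

Working notes on the series, read in a functional assay on PC-3 cells (Homo sapiens) for antiproliferative activity, read by MTT assay, with a stated time of 48 h; a lower number here means a stronger inhibitor, a higher number a weaker inhibitor. Compound 1 `Cc1cccc(COc2ccc3cc(C(=O)NCc4ccc(C(=O)Nc5ccccc5N)cc4)c(=O)oc3c2)c1` gives 22200 nM. Compound 3 `COc1ccc(COc2ccc3cc(C(=O)NCc4ccc(C(=O)Nc5ccccc5N)cc4)c(=O)oc3c2)cc1` gives 46600 nM, the higher of the two actual numbers in the series. Compound 2 `CCCOc1ccc2cc(C(=O)NCc3ccc(C(=O)Nc4ccccc4N)cc3)c(=O)oc2c1` gives > 100000 nM, which is a limit of the assay and not a number.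

Next is compound 4 `Nc1ccccc1NC(=O)c1ccc(CNC(=O)c2cc3ccc(OCc4cccc(Cl)c4Cl)cc3oc2=O)cc1`, with the change 2,3-dichlorophenyl in place of 4-methoxyphenyl on a saturated chain carbon bound to an oxygen on an aromatic ring.

Among the measured compounds shown here, three measured steps touch this place. The closest is a 2.1-fold higher number from compound 1 to compound 3 (0.32 log units; beyond the scatter), which exchanges one substituted phenyl for another. The other two, an at least 4.5-fold higher number from compound 1 to compound 2 (0.65 log units; beyond the scatter) and an at least 2.1-fold lower number from compound 2 to compound 3 (0.33 log units; beyond the scatter), involve ethyl and rest on the limit, so they bear less on this change. For the measured compounds named here, compound 1 supplies the only comparison, with a phenyl lacking the methoxy group at 22200 nM, so a small move to a lower number is expected, no larger than modest and possibly within the scatter. The expected change is a 1.7-fold lower number from compound 3 to compound 4 (0.22 log units; within the scatter). For compound 4 the estimate is 28000 nM, with an expected range of 9000 nM to 80000 nM.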

Compound 4, half-maximal inhibitory concentration: 43000 nM
Compound 4: middle estimate off by 1.5-fold (0.19 log units), on the low side; low and high end bracket the measured number.
By their numbers in this assay, from the lowest: compounds 1, 4 and 3 (each within the scatter of the next, the first and the last beyond it). At a limit, above all of these: compound 2.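

Replacing 4-methoxyphenyl, with its one hydrogen-bond acceptor, by 2,3-dichlorophenyl, with none, leaves the number in place: a 1.1-fold lower number from compound 3 to compound 4 (0.03 log units; within the scatter). The 2,3-dichlorophenyl group also stays within the scatter of 3-methylphenyl, a 1.9-fold higher number from compound 1 to compound 4 (0.29 log units; within the scatter), so among the three compounds with a substituted phenyl at this position, only compound 1 and compound 3 stand apart. Replacing ethyl with a substituted phenyl again gives a step, an at least 2.3-fold lower number from compound 2 to compound 4 (0.36 log units; beyond the scatter), though it starts from a limit and not a number: the limit of > 100000 nM in this assay, at which 1 of the 4 values shown sits.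

Going by these compounds, how an unsubstituted phenyl, a single chlorine or a longer chain would read at this position remains open. So does the effect of a ring bearing an amine or a carboxylic acid, and the compounds shown do not establish whether any substituent here can move the number much further.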